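This account rests on a few compounds, and the source may have more. Where it says the series, first, only, none or still open, it means among the compounds named here.

Measured so far: compound 1 `Oc1ccc(-c2cc(-c3cccc(F)c3)cc(-c3ccc(O)cc3)n2)cc1`, compound 2 `Oc1ccc(-c2cc(-c3ccc(F)cc3)cc(-c3ccc(O)cc3)n2)cc1`, compound 3 `Oc1ccc(-c2cc(-c3cccc(C(F)(F)F)c3)cc(-c3cccc(O)c3)n2)cc1`.

In a functional assay on HeLa cells (Homo sapiens) for inhibition (on this read-out higher numbers stand for weaker inhibition and lower numbers for stronger inhibition), compound 1 reaches only the limit > 50000 nM, so no number is known for it (the limit of > 50000 nM in this assay, at which 1 of the 3 values shown sits). Compound 2 gives 8680 nM and compound 3 gives 16200 nM; these two values lie within the scatter of each other, so neither can be called the better inhibitor. Compound 4 `Oc1ccc(-c2cc(-c3cccc(C(F)(F)F)c3)cc(-c3ccc(O)cc3)n2)cc1` differs from compound 3 by 4-hydroxyphenyl in place of 3-hydroxyphenyl on an aromatic carbon. Among the measured compounds shown here, the only comparable step is the shift of a fluorine from the 3- to the 4-position of a phenyl ring, which gave an at least 5.7-fold lower number from compound 1 to compound 2 (0.76 log units; beyond the scatter). The same kind of shift of the hydroxyl is therefore expected to lower the number for compound 4, as a 3.2-fold lower number from compound 3 to compound 4 (0.51 log units; beyond the scatter). Compound 4 is estimated at 5000 nM, between 1500 nM and 20000 nM.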

Compound 4, half-maximal inhibitory concentration: > 50000 nM
Compound 4: a limit, no number; the forecaster's own chance of this, stated with the estimate: 5%; middle value at least 10-fold (1.00 log units) away from the limit.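

In this assay, 4-hydroxyphenyl in place of 3-hydroxyphenyl next to the ring nitrogen weakens inhibition, with an at least 3.0-fold higher number from compound 3 to compound 4 (0.48 log units; beyond the scatter), so a shift to the 4-position does not help on this ring as it did for the fluorine. With two 4-hydroxyphenyl groups present, 3-(trifluoromethyl)phenyl in place of 4-fluorophenyl also weakens inhibition, with an at least 5.7-fold higher number from compound 2 to compound 4 (0.76 log units; beyond the scatter). The step between compound 1 and compound 4 cannot be read because both values are limits: the limit of > 50000 nM in this assay, at which 2 of the 4 values shown sit.

On these data alone, whether an aminophenyl or a methoxyphenyl group at this position would inhibit better remains open. So does whether 3-hydroxyphenyl would also outperform 4-hydroxyphenyl alongside 4-fluorophenyl.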